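Propyl to ethyl: compound 1 and compound 4

The compounds below may be only part of what the source reports. "The series", "measured", "known", "first", "only" and "open" are said of these compounds alone.

Among the compounds with values here, in a functional assay on MCF7 cells (Homo sapiens) for inhibition, read by sulforhodamine B assay (on this read-out lower numbers stand for stronger inhibition and higher numbers for weaker inhibition), compound 1 `CCCc1ccc(NC2=CC(=O)c3nc4n(c3C2=O)[C@H]2OC[C@@H](O)[C@H]2OC4)cc1` gives 4660 nM, the only true number in this small set. Compound 2 `O=C1C(Nc2ccccc2)=CC(=O)c2c1nc1n2[C@H]2OC[C@@H](O)[C@H]2OC1` reads > 4000 nM, which is a limit of the assay. Compound 3 `O=C1C(NC2CCCC2)=CC(=O)c2c1nc1n2[C@H]2OC[C@@H](O)[C@H]2OC1` reads > 16000 nM, which is also a limit. Compound 1 therefore cannot be ranked against either of the others.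

The next compound is compound 4 `CCc1ccc(NC2=CC(=O)c3nc4n(c3C2=O)[C@H]2OC[C@@H](O)[C@H]2OC4)cc1`. The change is hydrogen in place of methyl on a saturated chain carbon, two bonds along the chain from an aromatic carbon, so that 4-propylphenyl becomes 4-ethylphenyl.

Within the data shown here, the only measured step is a step that the two limits leave unreadable from compound 2 to compound 3. Among the measured compounds shown here, it has no readable size and involves a different change, so no measured step bears directly on this one. The starting point is compound 1 at 4660 nM, and no shift beyond the scatter is expected in this assay, in either direction. The expected step is a 1.0-fold lower number from compound 1 to compound 4 (0.02 log units; within the scatter). Compound 4 is estimated at 4500 nM, with an expected range of 2000 nM to 10000 nM.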

Compound 4, half-maximal inhibitory concentration: 960 nM
Compound 4: the middle estimate sits 4.7-fold (0.67 log units) above what was measured, and the stated range ends above it.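

Changing 4-propylphenyl to 4-ethylphenyl proves that this position is not silent in this assay: hydrogen in place of methyl on a saturated chain carbon, two bonds along the chain from an aromatic carbon, gives a 4.9-fold lower number from compound 1 to compound 4 (0.69 log units; beyond the scatter). Within the data shown here, this is the first step with a readable size, resting on two true numbers, whereas the earlier step between compound 2 and compound 3 cannot be read. Nothing at hand gives a measured reason for the size of this step.

Compound 2, with plain phenyl, reads > 4000 nM, which is a limit. Still open, as far as these compounds go, is how a 4-methylphenyl or a 4-butylphenyl group would read against compound 4, and so whether the change tracks chain length at all or belongs to the ethyl group alone.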